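Methyl on the Ring Carbon: Predicting Compound 4

The source may hold more compounds than are shown below. What is called first, only, known or untested is meant among the compounds shown, and "the series" means these compounds.

The measured compounds are:
compound 1, `COc1ccc(-c2cc(O)c3cccnc3n2)cc1`, 26300 nM
compound 2, `COc1ccccc1-c1cc(O)c2ccc(C)nc2n1`, 97700 nM
compound 3, `COc1ccccc1-c1cc(O)c2cccnc2n1`, 38900 nM

All three were tested in a functional assay on NCI-H460 cells (Homo sapiens); on this read-out higher numbers stand for weaker inhibition of growth and lower numbers for stronger inhibition of growth. Compound 1 has the lowest number of the three, but its value sits within the scatter of compound 3, so no order between those two can be claimed. Compound 2 stands apart: the step of a 2.5-fold higher number from compound 3 to compound 2 (0.40 log units; beyond the scatter) goes beyond the scatter, and the change behind it is methyl in place of hydrogen on an aromatic carbon.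

Compound 4, `COc1ccc(-c2cc(O)c3ccc(C)nc3n2)cc1`, has not been measured. It arises from compound 1 by methyl in place of hydrogen on an aromatic carbon. Going by the values given here, this is the same change as the one from compound 3 to compound 2: the place descriptions agree word for word. The two cores, that of compound 1 and that of compound 3, contain the same atoms joined differently; the difference between them is not broken down here.

Among the compounds with values here, with only one measured example of this change, the expectation for compound 4 rests on that single step. Compound 4 is expected to give a value near 65000 nM in this assay, a step of a 2.5-fold higher number from compound 1 to compound 4 (0.39 log units; beyond the scatter) from its parent, set beside the step of a 2.5-fold higher number from compound 3 to compound 2 (0.40 log units; beyond the scatter). Because the value of compound 1 is 26300 nM and the earlier step was modest, the estimated range for compound 4 runs from 30000 nM to 150000 nM. One pair of compounds is a thin base for transfer, so the range is kept wide.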

Compound 4, concentration for 50% growth inhibition: > 100000 nM
Compound 4: only a limit was reported; the forecaster's own chance of this, stated with the estimate: 20%; middle value at least 1.5-fold (0.18 log units) away from the limit.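

In this assay compound 4 returned only a limit of the assay, > 100000 nM, and not a number. On the core of compound 1, methyl in place of hydrogen on an aromatic carbon, next to the ring nitrogen, gave an at least 3.8-fold higher number from compound 1 to compound 4 (0.58 log units; beyond the scatter), so the higher number seen on the first core also appeared on the second, and in both cases the step lies beyond the scatter. The direction of the change therefore carried across these two cores, but this pair of examples does not establish a rule for the wider series, and it does not show whether the size of the step is the same on both: the same change on two cores in this assay, a 2.5-fold higher number (0.40 log units; beyond the scatter) from compound 3 to compound 2 and an at least 3.8-fold higher number (0.58 log units; beyond the scatter) from compound 1 to compound 4; the limit leaves it open whether they differ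

The compounds shown leave open how far the number for compound 4 lies past its limit, and so whether the core of compound 1 responds more strongly to the methyl group than the core of compound 3 does. They also leave open whether the loss of growth inhibition is specific to methyl or would also follow from another group in the same place, such as an amine, a carboxylic acid or a longer chain.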